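The source may report more compounds than this note shows. Statements on the series, on what has been measured and on what is new or still open speak of the compounds shown alone.

Three compounds have been measured in an assay for binding affinity to histamine H2 receptor (Homo sapiens); on this read-out higher numbers stand for weaker inhibition and lower numbers for stronger inhibition:
compound 1 `O=C(c1ccc(OCCCN2CCN(C(=O)[C@H]3CCCN3)CC2)cc1)C1CC1` gives 53700 nM;
compound 2 `CNCC(=O)N1CCN(CCCOc2ccc(C(=O)C3CC3)cc2)CC1` gives 79400 nM;
compound 3 `CN[C@@H](C(=O)N1CCN(CCCOc2ccc(C(=O)C3CC3)cc2)CC1)C(C)C` gives 49000 nM.

All three share the same core and differ only in the group carried by the carbonyl carbon that is joined to the amide-type nitrogen in the ring. Compound 3 shows the lowest of the three numbers, but each of its steps to the other two lies within the usual scatter, so no order of strength among them can be drawn. The steps themselves are small: a 1.5-fold higher number from compound 1 to compound 2 (0.17 log units; within the scatter), a 1.1-fold lower number from compound 1 to compound 3 (0.04 log units; within the scatter), and a 1.6-fold lower number from compound 2 to compound 3 (0.21 log units; within the scatter).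

Compound 4 `C[C@@H](NC(=O)OC(C)(C)C)C(=O)N1CCN(CCCOc2ccc(C(=O)C3CC3)cc2)CC1` has not yet been measured. It differs from compound 3 by 1-((tert-butoxycarbonyl)amino)ethyl in place of 2-methyl-1-(methylamino)propyl on a carbonyl carbon. All three measured steps bear on this change, since each of them alters the group at that same carbonyl carbon, and none of them moved the number beyond the scatter. The incoming group is larger than anything tried so far, so the measured steps offer only a loose guide. On this basis no step beyond the scatter is expected. Compound 4 is therefore estimated at 50000 nM, within a range from 15000 nM to 160000 nM. This estimate corresponds to an expected step of a 1.0-fold higher number from compound 3 to compound 4 (0.01 log units; within the scatter).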

Compound 4, inhibition constant: 83200 nM
The estimate for compound 4 lay 1.7-fold (0.22 log units) below the measured number, and the stated range covers the measured number.
By their numbers in this assay, from the lowest: compounds 3, 1, 2 and 4 (each within the scatter of the next).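

In this assay, 1-((tert-butoxycarbonyl)amino)ethyl brings 10 heavy atoms and 2 hydrogen-bond acceptors in place of the 6 heavy atoms and 1 acceptor of the group it replaces, yet the result stays within the scatter against every earlier compound: a 1.7-fold higher number from compound 3 to compound 4 (0.23 log units; within the scatter), a 1.0-fold higher number from compound 2 to compound 4 (0.02 log units; within the scatter) and a 1.5-fold higher number from compound 1 to compound 4 (0.19 log units; within the scatter). This extends the flat picture at this carbonyl carbon to a clearly larger group that contains oxygen and a double bond, so among the four groups shown, none separates from the others on this read-out. Nothing available here explains why these groups read alike.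

As far as these compounds go, how a carboxylic acid, a primary amine or a phenyl group would read on this carbonyl carbon remains open, and so does whether any group at this place can move the number beyond the scatter. All four compounds also keep the shared core unchanged, so the effect of a longer chain within that core is an open question as well.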